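A Bromophenyl Amide Gives Way to a Pyridyl Amide

The source may hold more compounds than are shown below. What is called first, only, known or untested is meant among the compounds shown, and "the series" means these compounds.

Compound 1 `COc1ccc(C(=O)Nc2ccccc2Br)cc1OC1CCCC1` shares its core with two measured relatives. In an assay on isolated protein for inhibition of phosphodiesterase 4A (Sus scrofa) (a lower number here means a stronger inhibitor, a higher number a weaker inhibitor), compound 1 gives 130 nM, the lowest number of the three shown. Compound 3 `COc1ccc(/C(S)=N/c2ccccc2Cl)cc1OC1CCCC1` gives 200 nM, within the scatter of compound 1. Compound 2 `COc1ccc(C(=O)Nc2ccccc2C(=O)c2ccccc2)cc1OC1CCCC1` gives 1700 nM; the one-place step a 13-fold higher number from compound 1 to compound 2 (1.12 log units; beyond the scatter) shows that exchanging the substituent on the ring held by the amide-type nitrogen can move the read-out a long way. Compound 4 `COc1ccc(C(=O)Nc2cccnc2)cc1OC1CCCC1` differs from compound 1 by pyridin-3-yl in place of 2-bromophenyl on an amide-type nitrogen. Going by the values given here, no measured step covers this exchange, and the bromine that compound 1 carries is lost entirely. A modest weakening is therefore expected: compound 4 is estimated at 400 nM, with a likely range of 130 nM to 1500 nM, which means an expected step of a 3.1-fold higher number from compound 1 to compound 4 (0.49 log units; beyond the scatter).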

Compound 4, half-maximal inhibitory concentration: 550 nM
Compound 4: the middle estimate sits 1.4-fold (0.14 log units) below what was measured, within the range that was stated.
By their numbers in this assay, from the lowest: compounds 1 and 3 (each within the scatter of the next); then compound 4; then compound 2.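

The step of a 4.2-fold higher number from compound 1 to compound 4 (0.63 log units; beyond the scatter) shows that this position on the amide-type nitrogen responds when the whole ring is exchanged, not only when a substituent on it changes. A ring holding one nitrogen atom and no bromine still leaves a modest change rather than a large one. Nothing available explains this step. On these data alone, the bromine leaves and the ring nitrogen enters in the same exchange, so the share of each in the step remains open. A plain phenyl group on the amide-type nitrogen would separate the two.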